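The source may report more compounds than this note shows. Statements on the series, on what has been measured and on what is new or still open speak of the compounds shown alone.

Of the compounds shown here, three that share one core have been measured in an assay on ileum with muscarinic acetylcholine receptor M3 (Cavia porcellus) as the target; a lower number here means a stronger inhibitor, a higher number a weaker inhibitor. Compound 1 `CCCc1nccn1CCC(C(N)=O)(c1ccccc1)c1ccccc1` gives 177 nM. Compound 2 `CC(C)c1nccn1CCC(C(N)=O)(c1ccccc1)c1ccccc1` gives 1.8 nM, and compound 3 `CCc1ncn(CCC(C(N)=O)(c2ccccc2)c2ccccc2)c1CC` gives 3.98 nM. Compound 3 therefore stands second of the three: its number is well below that of compound 1 and somewhat above that of compound 2. The steps among these three all touch the same group on the chain, and they are large: a 98-fold lower number from compound 1 to compound 2 (1.99 log units; beyond the scatter), a 44-fold lower number from compound 1 to compound 3 (1.65 log units; beyond the scatter), and the smaller 2.2-fold higher number from compound 2 to compound 3 (0.34 log units; beyond the scatter).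

Compound 4 `Cc1cn(CCC(C(N)=O)(c2ccccc2)c2ccccc2)cn1` is the next compound to be measured. It differs from compound 3 in one place: 4-methyl-1H-imidazol-1-yl in place of 4,5-diethyl-1H-imidazol-1-yl on a saturated chain carbon, three bonds along the chain from two aromatic carbons and a carbonyl carbon. Among the measured compounds shown here, no measured step changes exactly this part of the group, so the earlier steps show only that changes to this group can move this assay by a great deal in either direction. On that basis a moderate change is expected, a 2.5-fold higher number from compound 3 to compound 4 (0.40 log units; beyond the scatter), leaning toward a higher number. For compound 4 the expected value in this assay is 10 nM, with a likely range from 1.5 nM to 60 nM.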

Compound 4, antagonist equilibrium constant: 10.1 nM
The estimate for compound 4 lay 1.0-fold (0.00 log units) below the measured number, within the range that was stated.
By their numbers in this assay, from the lowest: compound 2; then compound 3; then compound 4; then compound 1.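

In this assay, the smaller group gives up only a modest amount, a 2.5-fold higher number from compound 3 to compound 4 (0.40 log units; beyond the scatter), even though 4-methyl-1H-imidazol-1-yl has 6 heavy atoms where 4,5-diethyl-1H-imidazol-1-yl has 9. The single methyl group also stays clearly better than the propyl-bearing group, an 18-fold lower number from compound 1 to compound 4 (1.24 log units; beyond the scatter), but does not match the isopropyl-bearing group, a 5.6-fold higher number from compound 2 to compound 4 (0.75 log units; beyond the scatter), so among these four, compound 1 stands far from the other three, which lie closer together. Nothing measured here explains why these groups rank in this order.

The compounds shown leave open which of the two ethyl groups accounts for the step from the diethyl to the methyl group. They also leave open how a plain 1H-imidazol-1-yl with no alkyl group, or a 2-methyl-1H-imidazol-1-yl, would compare.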